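Swapping the Furan Arm for a Fluoromethoxybenzyl Arm

This account rests on a few compounds, and the source may have more. Where it says the series, first, only, none or still open, it means among the compounds named here.

This study looks at how readily a basic amine in a shared core gives up a proton, measured by a physicochemical assay for acid dissociation. Compound 1, with the structure `CCC(CC)c1ccc2c(NCCCNCc3cc(F)ccc3OC)ccnc2c1`, gives a value of 9.47 in this assay. Compound 2, with the structure `c1ccc(-c2ccc3c(NCCCNCc4ccco4)ccnc3c2)cc1`, gives 9.47 in this assay. Compound 2 therefore stands level with compound 1 at the digits shown, the two values lying within the scatter of the method, so no order can be read between them.

Compound 3, with the structure `COc1ccc(F)cc1CNCCCNc1ccnc2cc(-c3ccccc3)ccc12`, has not yet been measured. It differs from compound 2 in one place: 5-fluoro-2-methoxyphenyl in place of furan-2-yl on a saturated chain carbon bound to an amine nitrogen. The remainder of the molecule, including the amine chain and the shared core, is unchanged. Within the data shown here, no measured pair in this set isolates this particular change, so its effect on the proton-releasing behaviour has to be guessed from the two values in hand, which agree with each other.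

For compound 3 the expectation is a step of a number 0.03 log units higher from compound 2 to compound 3 (within the scatter) in this assay, that is, none beyond the scatter. Compound 3 is thus estimated at 9.5 in this assay, with a range from 9.1 to 9.9.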

Compound 3, acid dissociation constant: 9.47
Beside the measured number, compound 3's estimate is 0.03 log units above it, within the range that was stated.
By their numbers in this assay, from the lowest: compounds 1, 2 and 3 (each within the scatter of the next).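

In this assay, among these compounds, the larger 5-fluoro-2-methoxyphenyl group in place of furan-2-yl, on a saturated chain carbon bound to an amine nitrogen, gives no change at the digits printed from compound 2 to compound 3 (within the scatter) and so provides the first direct reading of this swap, where the earlier compounds offered only two values differing in more than one place. A second single change can now be read as well: phenyl in place of pentan-3-yl on an aromatic carbon gives no change at the digits printed from compound 1 to compound 3 (within the scatter), so neither swap moves the read-out beyond the scatter, even though each exchanges one group for a quite different one. No measurement shown here explains why the read-out holds steady at either place.

The compounds shown carry only aromatic rings at the chain position, so it remains open whether the read-out would hold with an amine or a carboxylic acid there, or with a longer chain joining the two amine nitrogens. On the aromatic carbon, only phenyl and pentan-3-yl appear, which leaves a group such as a nitrile or a trifluoromethyl as an open case.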